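Butylcarbonyl in place of 2-hydroxyethyl on the shared core

The source may report more compounds than this note shows. Statements on the series, on what has been measured and on what is new or still open speak of the compounds shown alone.

In a functional assay on A-375 cells (Homo sapiens) for cytotoxicity, read by MTT assay (on this read-out lower numbers stand for stronger inhibition and higher numbers for weaker inhibition), compound 1 `COc1ccc(/C=C/C(=O)c2ccc(OC)c3c2OC(C)(C)C=C3)cc1O` gives 800 nM. Compound 2 `C=CCOc1cc(/C=C/C(=O)c2ccc(OC)c3c2OC(C)(C)C=C3)ccc1OC` reaches only a limit, > 10000 nM. Compound 3 `COc1ccc(/C=C/C(=O)c2ccc(OC)c3c2OC(C)(C)C=C3)cc1OCCO` gives 9600 nM, the higher of the two exact numbers and so the weaker result. Replacing the hydrogen on the oxygen costs much in both cases: an at least 12-fold higher number from compound 1 to compound 2 (1.09 log units; beyond the scatter) with allyl, and a 12-fold higher number from compound 1 to compound 3 (1.08 log units; beyond the scatter) with 2-hydroxyethyl. Compound 4 `CCCCC(=O)Oc1cc(/C=C/C(=O)c2ccc(OC)c3c2OC(C)(C)C=C3)ccc1OC` has butylcarbonyl in place of 2-hydroxyethyl on an oxygen on an aromatic ring. That oxygen still carries no hydrogen, so the large loss in a 12-fold higher number from compound 1 to compound 3 (1.08 log units; beyond the scatter) is expected to remain. The expected change is a 1.6-fold lower number from compound 3 to compound 4 (0.20 log units; within the scatter), no step beyond the scatter. For compound 4 the estimate is 6000 nM, within a range of 2000 nM to 18000 nM.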

Compound 4, half-maximal inhibitory concentration: 220 nM
For compound 4 the middle estimate is 27-fold (1.44 log units) above the measured one; the measured number lies below the stated range.
By their numbers in this assay, from the lowest: compound 4; then compound 1; then compound 3. At a limit, above all of these: compound 2.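

The oxygen does not need its hydrogen: butylcarbonyl there gives a 3.6-fold lower number from compound 1 to compound 4 (0.56 log units; beyond the scatter), so the losses with allyl and 2-hydroxyethyl do not apply to every group at this position. The choice of group decides the outcome, with a 44-fold lower number from compound 3 to compound 4 (1.64 log units; beyond the scatter) and an at least 45-fold lower number from compound 2 to compound 4 (1.65 log units; beyond the scatter). That last step rests on a limit for compound 2: the limit of > 10000 nM in this assay, at which 1 of the 4 values shown sits.

From the compounds shown here alone, it remains open whether the carbonyl or the butyl part of the new group matters more. Acetyl or a longer acyl chain on this oxygen would help to separate the two.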